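The source may hold more compounds than are shown below. What is called first, only, known or untested is meant among the compounds shown, and "the series" means these compounds.

Working notes on the series. In a functional assay on A549 cells (Homo sapiens) for antiproliferative activity, read by MTT assay (a higher number here means a weaker inhibitor, a lower number a stronger inhibitor), compound 1 (`COc1cc2c(Oc3ccc(NC(=O)Nc4ccccc4Cl)cc3)ccnc2cc1OCCCCCCC(=O)NO`) gives 1910 nM and compound 2 (`COc1cc2c(Oc3ccc(NC(=O)Nc4cccc(C)c4)cc3)ccnc2cc1OCCCCCCC(=O)NO`) gives 2010 nM. The 3-methylphenyl change is a 1.1-fold higher number from compound 1 to compound 2 (0.02 log units; within the scatter), so compound 1 shares the low end of the numbers with compound 2. Among the compounds with values here, compound 3 (`COc1cc2c(Oc3ccc(NC(=O)Nc4ccc(Cl)c(C(F)(F)F)c4)cc3)ccnc2cc1OCCCCCCC(=O)NO`) gives 5020 nM, the highest number so far. The 4-chloro-3-(trifluoromethyl)phenyl change is a 2.6-fold higher number from compound 1 to compound 3 (0.42 log units; beyond the scatter), and the comparison with the 3-methylphenyl analogue is a 2.5-fold higher number from compound 2 to compound 3 (0.40 log units; beyond the scatter).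

Compound 4 (`COc1cc2c(Oc3ccc(NC(=O)NC4CCCCC4)cc3)ccnc2cc1OCCCCCCC(=O)NO`) has not yet been measured. Its change from compound 1 is cyclohexyl in place of 2-chlorophenyl on an amide-type nitrogen. The measured steps bear on this only indirectly, as each exchanges one six-membered aromatic ring of carbon only for another. None tests a non-aromatic ring at this place. Those steps run from within the scatter to modest, and both steps beyond the scatter lead to compound 3. In this assay, a small move towards a higher number is therefore expected, possibly not beyond the scatter. The expected change is a 1.6-fold higher number from compound 1 to compound 4 (0.20 log units; within the scatter). For compound 4, the estimated value is 3000 nM, with an expected range of 1100 nM to 8000 nM.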

Compound 4, half-maximal inhibitory concentration: 850 nM
Estimate against measurement, compound 4: 3.5-fold (0.55 log units) above; the measured number lies below the stated range.
By their numbers in this assay, from the lowest: compound 4; then compounds 1 and 2 (each within the scatter of the next); then compound 3.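

In this assay, within the data shown here, an aromatic ring is not required on this amide-type nitrogen for the lowest number so far: cyclohexyl falls below all three aryl groups (first a 2.2-fold lower number from compound 1 to compound 4 (0.35 log units; beyond the scatter)), (then a 2.4-fold lower number from compound 2 to compound 4 (0.37 log units; beyond the scatter)) and (furthest a 5.9-fold lower number from compound 3 to compound 4 (0.77 log units; beyond the scatter)). The earlier steps shown here only exchanged one six-membered aromatic ring of carbon only for another, and all of them stayed level or moved to a higher number, whereas this first non-aromatic ring at the place moves the number lower. No measurement on hand speaks to the cause of this shift.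

The step from compound 1 to compound 4 removes the chlorine and the aromatic ring together, so the compounds shown do not say which of the two changes carries it, and a plain unsubstituted phenyl on the same nitrogen would separate them. Also open, as far as these compounds go, is whether a ring is needed at all or whether other saturated groups follow cyclohexyl, as an open n-hexyl chain, a smaller cyclopentyl ring or a piperidine ring carrying a basic amine would show.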